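From Allyloxy to Propargyloxy at a Limit

This account rests on a few compounds, and the source may have more. Where it says the series, first, only, none or still open, it means among the compounds named here.

Compound 3 (`C=CCOC1=CC(=O)S[C@]1(C)CCCCCC`) gives > 50 ug/mL in a functional assay on MCF7 cells (Homo sapiens) for inhibition (on this read-out lower numbers stand for stronger inhibition and higher numbers for weaker inhibition), as a limit of the assay and not a number. Compound 1 (`CCCCCC[C@@]1(C)SC(=O)C=C1OC`) reads 14 ug/mL and compound 2 (`CCCCCC[C@@]1(C)SC(=O)C=C1OCC(=O)OCC`) reads 14.2 ug/mL on the same scale. The step between these two is small (a 1.0-fold higher number from compound 1 to compound 2 (0.01 log units; within the scatter)), while the steps to the vinyl-bearing compound 3 are larger (an at least 3.5-fold higher number from compound 1 to compound 3 (0.55 log units; beyond the scatter)) and (an at least 3.5-fold higher number from compound 2 to compound 3 (0.54 log units; beyond the scatter)).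

Compound 4 (`C#CCOC1=CC(=O)S[C@]1(C)CCCCCC`) differs from compound 3 in one place (ethynyl in place of vinyl on a saturated chain carbon bound to an oxygen on an unsaturated carbon), with ethynyl in place of vinyl on a saturated chain carbon bound to an oxygen on an unsaturated carbon. Going by the values given here, no measured step makes this exchange, so those steps bear on it only loosely. They show that the number in this assay can move with the group at this place. The expected step is a modest one toward stronger inhibition (an at least 1.5-fold lower number from compound 3 to compound 4 (0.19 log units; that floor lies within the scatter)) and it may not clear the limit. Compound 4 is expected near 32 ug/mL within an estimated range of 14 ug/mL to 50 ug/mL and could also return only a limit.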

Compound 4, half-maximal inhibitory concentration: 21.9 ug/mL
Compound 4: the middle estimate sits 1.5-fold (0.16 log units) above what was measured; measured number inside the range.
By their numbers in this assay, from the lowest: compounds 1, 2 and 4 (each within the scatter of the next). At a limit, above all of these: compound 3.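

Exchanging vinyl for ethynyl leaves the count of heavy atoms unchanged and alters only the bond at the end of the chain, yet in this assay that one exchange is enough to bring a number back from the limit (an at least 2.2-fold lower number from compound 3 to compound 4 (0.35 log units; beyond the scatter)). The ethynyl group also sits level with the two groups that gave measurable numbers (a 1.5-fold higher number from compound 2 to compound 4 (0.19 log units; within the scatter)) and (a 1.6-fold higher number from compound 1 to compound 4 (0.19 log units; within the scatter)), so the loss seen with allyloxy does not extend to every unsaturated chain at this place. Going by these compounds alone, compound 3 remains the only compound here at a limit of the assay, which is not a number: the limit of > 50 ug/mL in this assay, at which 1 of the 4 values shown sits.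

As far as these compounds go, the true size of the allyloxy to propargyloxy step therefore stays open. Also open, from the compounds shown here alone, is whether a longer chain, an amine or a carboxylic acid at this place would keep the reading of compound 4.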